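Amide nitrogen substituents and tolerated concentration in the series

The source may report more compounds than this note shows. Statements on the series, on what has been measured and on what is new or still open speak of the compounds shown alone.

Compound 1 `CC(C)(C)c1ccc(N(C(=O)c2ccco2)C(C(=O)NC2CC2)c2cccnc2)cc1` gives 52800 nM in a toxicity assay on Vero C1008 cells (Chlorocebus sabaeus) for cytotoxicity, read by neutral red uptake, with a stated time of 5 days; a lower number here means that less compound is tolerated, a higher number that more compound is tolerated. Compound 3 `CC(C)(C)CC(C)(C)NC(=O)C(c1cccnc1)N(C(=O)c1ccco1)c1ccc(-c2ccccc2)cc1` gives 148000 nM in this assay. Compound 2 `C[C@H](NC(=O)C(c1cccnc1)N(C(=O)c1ccco1)c1ccc(-c2ccccc2)cc1)c1ccccc1` is recorded in this assay only as a limit of the assay, > 200000 nM. Of the two numbers available, compound 3 holds the higher and compound 1 the lower, and that gap lies beyond the scatter. Among the measured compounds shown here, the one measured change at the amide-type nitrogen, an at least 1.3-fold lower number from compound 2 to compound 3 (0.13 log units; that floor lies within the scatter), is bounded by the limit for compound 2 the limit of > 200000 nM in this assay, at which 1 of the 3 values shown sits, and its floor lies within the scatter, so it gives no reliable direction for changes at this position.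

Compound 4 `O=C(NC1CCCCC1)C(c1cccnc1)N(C(=O)c1ccco1)c1ccc(-c2ccccc2)cc1` differs from compound 3 by cyclohexyl in place of 1,1,3,3-tetramethylbutyl on an amide-type nitrogen. For the measured compounds named here, the only step that bears on this position is an at least 1.3-fold lower number from compound 2 to compound 3 (0.13 log units; that floor lies within the scatter), which did not rise clearly out of the scatter, and the difference between compound 3 and compound 4 is of a similar kind, an exchange of one non-polar group for another on the amide-type nitrogen. The change from compound 3 to compound 4 is therefore expected to give no step beyond the scatter in this assay, a 1.3-fold lower number from compound 3 to compound 4 (0.13 log units; within the scatter). Compound 4 is expected to give about 110000 nM in this assay, most likely between 45000 nM and 200000 nM, with some chance that the assay reports only a limit.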

Compound 4, half-maximal cytotoxic concentration: 53500 nM
Compound 4: middle estimate off by 2.1-fold (0.31 log units), on the high side; low and high end bracket the measured number.
By their numbers in this assay, from the lowest: compounds 1 and 4 (each within the scatter of the next); then compound 3. At a limit, above all of these: compound 2.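

In this assay, among the compounds shown here, the substituent on the amide-type nitrogen now produces a step that clears the scatter: a 2.8-fold lower number from compound 3 to compound 4 (0.44 log units; beyond the scatter), with cyclohexyl in place of 1,1,3,3-tetramethylbutyl, whereas the only earlier step at this position had a floor within the scatter. Cyclohexyl in place of 1-phenylethyl gives a second step with a floor beyond the scatter, an at least 3.7-fold lower number from compound 2 to compound 4 (0.57 log units; beyond the scatter), so the position is not indifferent to the exchange of one carbon-only group for another, at least among these compounds. That second step is only a floor, compound 2 being recorded solely as a limit of the assay: the limit of > 200000 nM in this assay, at which 1 of the 4 values shown sits.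

The step from compound 3 to compound 4 changes the ring and the carbon count together, and the compounds shown do not separate the two, as an open hexyl chain on the same nitrogen would. Every group on this nitrogen here is built on carbon alone, which leaves open where a cyclohexyl carrying an amine or a carboxylic acid would stand in this assay.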